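The compounds below may be only part of what the source reports. "The series", "measured", "known", "first", "only" and "open" are said of these compounds alone.

For the measured compounds named here, compound 1 `C#Cc1cn([C@@H]2O[C@H](CO)[C@@H](O)[C@H]2O)c2ncnc(N(C)C)c12` holds the lowest of the two numbers so far in a functional assay on HepG2 cells (Homo sapiens) for antiproliferative activity, read by XTT assay, with a stated time of 72 h (a higher number here means a weaker inhibitor, a lower number a stronger inhibitor), where compound 1 gives 1320 nM. Compound 2 `C#Cc1cn([C@@H]2O[C@H](CO)[C@@H](O)[C@H]2O)c2ncnc(OC)c12` gives 12700 nM in this assay, and the step of a 9.6-fold higher number from compound 1 to compound 2 (0.98 log units; beyond the scatter) swaps methoxy for dimethylamino, a site left untouched in compound 3 `CN(C)c1ncnc2c1c(-c1cccs1)cn2[C@@H]1O[C@H](CO)[C@@H](O)[C@H]1O`. The change to compound 3 is thiophen-2-yl in place of ethynyl on an aromatic carbon. Going by the values given here, no measured step touches the ethynyl position, so the direction is uncertain and only a modest shift is expected. Compound 3 is estimated at 1500 nM in this assay, between 300 nM and 8000 nM, so a 1.1-fold higher number from compound 1 to compound 3 (0.06 log units; within the scatter) is expected.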

Compound 3, half-maximal inhibitory concentration: > 20000 nM
Compound 3: a limit, no number (the forecaster's own chance of this, stated with the estimate: 5%); at least 13-fold (1.12 log units) between middle value and limit.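

The earlier step changed only the dimethylamino site, and this one shows that the ethynyl position matters too: with dimethylamino kept, thiophen-2-yl in place of ethynyl gives an at least 15-fold higher number from compound 1 to compound 3 (1.18 log units; beyond the scatter). A single change on this aromatic carbon is therefore enough to weaken the compound clearly in this assay. Compound 3 has a limit rather than a number: the limit of > 20000 nM in this assay, at which 1 of the 3 values shown sits.

Still open, on these data alone, is whether any ring on this carbon has this result, or only thiophen-2-yl. A phenyl or furan-2-yl group here, or a longer chain ending in a triple bond, would help separate these possibilities.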